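Replacing piperidin-3-yl with (pyridin-2-yl)methyl in compound 2

The compounds below may be only part of what the source reports. "The series", "measured", "known", "first", "only" and "open" are said of these compounds alone.

Compound 1 `O=C(NCC1CCCCN1)c1ccc(-c2cc(F)c3ncc(Cc4ccc5ncccc5c4)n3c2)cc1F`: 277 nM
Compound 2 `O=C(NC1CCCNC1)c1ccc(-c2cc(F)c3ncc(Cc4ccc5ncccc5c4)n3c2)cc1F`: 138 nM

For the measured compounds named here, in a functional assay on EBC-1 cells (Homo sapiens) for antiproliferative activity, with a stated time of 72 h (on this read-out lower numbers stand for stronger inhibition and higher numbers for weaker inhibition), compound 2 gives 138 nM, and the only other measured number cannot be told apart from it: the single measured step is a 2.0-fold lower number from compound 1 to compound 2 (0.30 log units; within the scatter). The next compound, compound 3 `O=C(NCc1ccccn1)c1ccc(-c2cc(F)c3ncc(Cc4ccc5ncccc5c4)n3c2)cc1F`, has (pyridin-2-yl)methyl in place of piperidin-3-yl on an amide-type nitrogen. The measured step bears on this only loosely. Going by the values given here, it exchanged (piperidin-2-yl)methyl for piperidin-3-yl at the same place, while no measured compound carries an aromatic ring there. With so little to go on, no step beyond the scatter is expected in either direction, though the uncertainty is wide. The expected step in this assay is a 1.4-fold lower number from compound 2 to compound 3 (0.14 log units; within the scatter). The estimate for compound 3 is 100 nM, with an expected range from 25 nM to 400 nM.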

Compound 3, half-maximal inhibitory concentration: 5550 nM
Estimate against measurement, compound 3: 56-fold (1.74 log units) below, and the stated range ends below it.
By their numbers in this assay, from the lowest: compounds 2 and 1 (each within the scatter of the next); then compound 3.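

In this assay the position on the amide-type nitrogen proves sensitive to the group it carries: the two compounds with a piperidine ring could not be told apart, yet (pyridin-2-yl)methyl in place of piperidin-3-yl gives a 40-fold higher number from compound 2 to compound 3 (1.60 log units; beyond the scatter), a large loss of activity. With the saturated chain carbon kept, pyridin-2-yl in place of piperidin-2-yl gives a 20-fold higher number from compound 1 to compound 3 (1.30 log units; beyond the scatter), so changing the ring alone is enough for a large step. Nothing measured here explains this loss.

On these data alone, it remains open whether the aromatic ring itself counts against activity, or whether the hydrogen-bond donor of the piperidine ring, absent from the pyridine ring, is what matters. A cyclohexyl ring, a phenyl ring or an open-chain amine such as 2-aminoethyl on the same nitrogen would help separate these two readings.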